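This account rests on a few compounds, and the source may have more. Where it says the series, first, only, none or still open, it means among the compounds named here.

Compound 1 `CC(C)=CCC[C@](C)(O)c1ccc(C)cc1`: in a functional assay on HepG2 cells (Homo sapiens) for inhibition, read by fluorescence, with a stated time of 60 min (a lower number here means a stronger inhibitor, a higher number a weaker inhibitor), compound 1 gives the limit > 100000 nM.
Compound 2 `Cc1ccc([C@]2(C)CC[C@@H](C(C)(C)O)O2)cc1`: in this assay compound 2 gives the limit > 100000 nM.

Compound 2 thus stands at the limit of > 100000 nM in this assay, at which 2 of the 2 values shown sit, and no number has been obtained for it. Compound 3 `Cc1ccc([C@]2(C)CC[C@@H](C(C)(C)O)O2)cc1O` differs from compound 2 by hydroxy in place of hydrogen on an aromatic carbon. With both measured values resting at the limit, the step that the limit leaves unreadable from compound 2 to compound 3 is expected to be none beyond the scatter. Compound 3 is therefore estimated at 150000 nM, in the range 30000 nM to 1000000 nM, most likely again reported only as a limit.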

Compound 3, half-maximal inhibitory concentration: 18000 nM
Compound 3: middle estimate off by 8.3-fold (0.92 log units), on the high side; the measured number lies below the stated range.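

In this assay, the aromatic carbon ortho to a methyl group proves to be a place where a change registers: hydroxy in place of hydrogen there gives an at least 5.5-fold lower number from compound 2 to compound 3 (0.74 log units; beyond the scatter). Compound 3 therefore holds the only true number among the three compounds shown. The full size of the step remains unknown, as compound 2 is held only by a limit: the limit of > 100000 nM in this assay, at which 2 of the 3 values shown sit.

The compounds shown leave open whether a methoxy group or an amine on the same carbon would also give a measurable number. They also leave open whether hydroxy would have the same effect on the open chain of compound 1.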